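The source may hold more compounds than are shown below. What is called first, only, known or untested is meant among the compounds shown, and "the series" means these compounds.

Measured compounds and their values:
compound 1, `N#C/C(=C\c1c(-c2ccccc2)[nH]c2ccccc12)C(=O)c1ccccc1`, 5200 nM;
compound 2, `COc1ccc(-c2[nH]c3ccc(OC)cc3c2/C=C(\C#N)S(=O)(=O)c2ccccc2)cc1`, 875 nM;
compound 3, `COc1ccc2[nH]c(-c3ccccc3)c(C=C(C#N)C#N)c2c1`, 6500 nM.

In a functional assay on DU-145 cells (Homo sapiens) for inhibition, read by sulforhodamine B assay, with a stated time of 48 h (a higher number here means a weaker inhibitor of growth, a lower number a stronger inhibitor of growth), compound 1 gives 5200 nM, the second highest of the three numbers. Compound 3 with 6500 nM lies closest to it, within the usual scatter, so no order can be read between these two. Compound 2, which carries a phenylsulfonyl group together with two methoxy groups, gives 875 nM, a gap from compound 1 that is beyond the scatter.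

Compound 4, `N#C/C(=C\c1c(-c2ccccc2)[nH]c2ccccc12)S(=O)(=O)c1ccccc1`, has not yet been measured in this assay. It differs from compound 1 in one place: phenylsulfonyl in place of benzoyl on a double-bonded chain carbon bound to a double-bonded chain carbon and a triple-bonded carbon. Among the measured compounds shown here, no step between measured compounds covers this exact change, since compound 2 differs from compound 4 in more than one place. For the measured compounds named here, still, the only sulfonyl-bearing compound among the measured three, compound 2, shows the lowest number. A step downward from compound 1 of moderate size is therefore expected for compound 4, a 2.6-fold lower number from compound 1 to compound 4 (0.41 log units; beyond the scatter). Compound 4 is estimated at 2000 nM, within a range from 700 nM to 6000 nM.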

Compound 4, concentration for 50% growth inhibition: 2900 nM
For compound 4 the middle estimate is 1.5-fold (0.16 log units) below the measured one; the range from low to high includes it.
By their numbers in this assay, from the lowest: compound 2; then compounds 4, 1 and 3 (each within the scatter of the next, the first and the last beyond it).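

Among the compounds shown here, at this position, on a double-bonded chain carbon bound to a double-bonded chain carbon and a triple-bonded carbon, exchanging benzoyl for phenylsulfonyl gives the first direct comparison in this assay: a 1.8-fold lower number from compound 1 to compound 4 (0.25 log units; within the scatter). Since this step lies within the scatter, no order can be read between the two compounds, and on this core phenylsulfonyl does not measurably set compound 4 apart from compound 1. Nothing measured here offers an explanation for this result.

The compounds shown leave open whether another group at this position, such as an amine, a carboxylic acid or a longer chain, would shift the number beyond the scatter. Also open is what the methoxy groups of compound 2 contribute on their own, a question that no pair shown isolates.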